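Compound 4: second 5-(nitrooxy)pentyl group on compound 2

A few compounds are considered here, and "the series" means these few. Any claim that something is new, unique, unknown or untested is made for them only; others in the source may bear on it.

Measured so far in a functional assay on M14 cells (Homo sapiens) for cytotoxicity, read by resazurin assay, with a stated time of 72 h; on this read-out lower numbers stand for stronger inhibition and higher numbers for weaker inhibition

compound 1 `O=C(/C=C/c1ccc(OCCCCCO[N+](=O)[O-])c(O)c1)OCCCCCO[N+](=O)[O-]` gives > 50000 nM as a limit of the assay, not a number
compound 2 `COc1cc(/C=C/C(=O)OCCCCCO[N+](=O)[O-])ccc1O` gives 24500 nM
compound 3 `COc1cc(/C=C/C(=O)OCCCO[N+](=O)[O-])ccc1O` gives 42600 nM

Going by the values given here, compound 2 stands at 24500 nM as one of only two true numbers. Among the compounds with values here, the single measured step (a 1.7-fold higher number from compound 2 to compound 3 (0.24 log units; within the scatter)) lies on a saturated chain carbon and stays within the scatter. It says little about the site changed next.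

Compound 4 `COc1cc(/C=C/C(=O)OCCCCCO[N+](=O)[O-])ccc1OCCCCCO[N+](=O)[O-]` comes from compound 2 by one change (5-(nitrooxy)pentyl in place of hydrogen on an oxygen on an aromatic ring), namely 5-(nitrooxy)pentyl in place of hydrogen on an oxygen on an aromatic ring. Within the data shown here, no measured step covers this change directly. The nearest guide is compound 1, which also carries 5-(nitrooxy)pentyl on an oxygen on an aromatic ring. In this assay compound 1 reads > 50000 nM and this is a limit. On the strength of compound 1 at > 50000 nM a modest rise in the number is expected, and a reading that is only a limit remains possible. The expected step is a 1.8-fold higher number from compound 2 to compound 4 (0.26 log units; within the scatter) towards weaker inhibition and may not clear the scatter. For compound 4 the estimated value is 45000 nM with an estimated range from 18000 nM to 110000 nM in this assay.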

Compound 4, half-maximal inhibitory concentration: > 50000 nM
Compound 4: a limit, no number (the forecaster's own chance of this, stated with the estimate: 45%); middle value at least 1.1-fold (0.04 log units) away from the limit.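

In this assay, going by these compounds alone, the change from hydroxy to (5-(nitrooxy)pentyl)oxy gives an at least 2.0-fold higher number from compound 2 to compound 4 (0.30 log units; that floor lies within the scatter), which is the first step read at an oxygen on an aromatic ring, as the earlier step lay on a saturated chain carbon. As far as these compounds go, compound 4 reads > 50000 nM, which is a limit and not a number, so the true size of this step is unknown and its floor alone does not establish a real change at this position. Compound 1 and compound 4 both sit at the same limit, so the step between them, which would test methyl in place of hydrogen on the other oxygen on the aromatic ring, cannot be read: the limit of > 50000 nM in this assay, at which 2 of the 4 values shown sit.

The compounds shown leave open how far compound 4 lies beyond the limit, and so whether this change has any effect larger than the scatter. They also leave open whether any such effect belongs to the nitrooxy end or to the chain itself, a question that a plain pentyl chain or a small acetyl group on the same oxygen would address in this assay.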